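This account rests on a few compounds, and the source may have more. Where it says the series, first, only, none or still open, it means among the compounds named here.

Measured compounds:
- compound 1, `NCc1cc(O[C@@H]2CCCN(C(=O)Nc3ccccc3)C2)nc(C(F)(F)F)c1` — in an ADME assay on the whole organism (plasma, Mus musculus) for pharmacokinetics, read by LC-MS, at a dose of 30 mg/kg by the oral route (on this read-out higher numbers stand for higher exposure at the dose given and lower numbers for lower exposure), compound 1 stands at "not determined" (no result reported)
- compound 2, `NCc1cc(Oc2cccc(C(=O)N3CC[C@@H](N)C3)c2)nc(C(F)(F)F)c1` — in this assay compound 2 gives 670 nM
- compound 3, `CONC(=O)c1cccc(Oc2cc(CN)cc(C(F)(F)F)n2)c1` — in this assay compound 3 gives 630 nM

Going by the values given here, compound 1 thus carries no number in this assay; its only footing is that compounds 2 and 3, which share its core, both sit in the same region of maximal plasma concentration. Among the compounds with values here, the one step measured, a 1.1-fold lower number from compound 2 to compound 3 (0.03 log units; within the scatter), shows that exchanging the amide substituent there left the read-out unchanged in practice.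

Compound 4, `NCc1cc(O[C@H]2CCCN(C(=O)Nc3ccccc3)C2)nc(C(F)(F)F)c1`, is the stereoisomer of compound 1: the two compounds have the same atoms and bonds and differ only in configuration as drawn: 1 of 1 stereo elements differ; a stereocentre at a saturated ring carbon is drawn R in compound 1 and S in compound 4. Within the data shown here, no measured step bears on this change directly; the only step on record concerns a different part of the molecule, and it was flat. With no value for compound 1, no direction can be inferred for compound 4, and the working assumption is that compound 4 lands near the level set by compounds 2 and 3 in this assay, with a wide margin because the carbamoyl-piperidinyl ether side chain of compound 4 is not represented by any measured compound.

For compound 4 the expected maximal plasma concentration in this assay is 600 nM, estimated to lie between 120 nM and 3000 nM.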

Compound 4, maximal plasma concentration: 1900 nM
The estimate for compound 4 lay 3.2-fold (0.50 log units) below the measured number; low and high end bracket the measured number.
By their numbers in this assay, from the lowest: compounds 3 and 2 (each within the scatter of the next); then compound 4.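

In this assay compound 4 gives 1900 nM, but no new step can be read between compound 1 and compound 4. The compounds shown leave open whether the configuration drawn at the saturated ring carbon shifts maximal plasma concentration at all, and the one pair that bears on this question is defined by a single feature: the fact that compounds 1 and 4 differ only in the configuration as drawn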